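Swapping 5-methylpyridin-2-yl for 1,3-benzothiazol-2-yl

The source may report more compounds than this note shows. Statements on the series, on what has been measured and on what is new or still open speak of the compounds shown alone.

Compound 1 `COc1nc2cccnc2n1-c1ccc(Nc2ccc(C)cn2)cc1`: 34 mL.min-1.g-1
Compound 2 `COc1nc2cccnc2n1-c1ccc(Nc2ccc3ccccc3n2)cc1`: 57 mL.min-1.g-1

Both compounds were tested in an ADME assay (liver) for metabolic stability, with Liver microsome (Homo sapiens) as the target, read by LC-MS, using microsomes and NADPH, with a stated time of 30 min, tested at 1 uM; a lower number here means slower removal, a higher number faster removal of the compound. Their two values lie within the usual scatter of repeated measurements, so compound 1 stands level with compound 2 and the pair cannot be ranked.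

Compound 3 `COc1nc2cccnc2n1-c1ccc(Nc2nc3ccccc3s2)cc1`, not yet measured, shares the core of compound 1 but carries 1,3-benzothiazol-2-yl in place of 5-methylpyridin-2-yl on a nitrogen on an aromatic ring. For the measured compounds named here, no measured pair isolates a single change, so there is no direct guide to this swap. Going by the values given here, the only evidence is the narrow spread of the two known values, compound 1 at 34 mL.min-1.g-1 and compound 2 at 57 mL.min-1.g-1. On that basis, no step beyond the scatter is expected in this assay. The expected change is a 1.5-fold higher number from compound 1 to compound 3 (0.17 log units; within the scatter). For compound 3 the estimated value is 50 mL.min-1.g-1, with an expected range of 22 mL.min-1.g-1 to 110 mL.min-1.g-1.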

Compound 3, intrinsic clearance in microsomes: 65 mL.min-1.g-1
For compound 3 the middle estimate is 1.3-fold (0.11 log units) below the measured one; measured number inside the range.
By their numbers in this assay, from the lowest: compounds 1, 2 and 3 (each within the scatter of the next).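

In this assay, for the compounds shown here, the swap from 5-methylpyridin-2-yl to 1,3-benzothiazol-2-yl gives a 1.9-fold higher number from compound 1 to compound 3 (0.28 log units; within the scatter) and so, for the first time, a single change at this place on the nitrogen can be read directly. Exchanging one six-membered aromatic ring for a five-membered aromatic ring plus a six-membered one, with sulfur added, leaves the number level with that of compound 1 within the scatter. Nothing shown here bears on the reason for this result.

As far as these compounds go, the swap alters the rings and adds sulfur in one step, so the share of each part remains unknown. Also open, from the compounds shown here alone, is how the number would respond to a plain phenyl ring on this nitrogen, or to a chain ending in an amine or a carboxylic acid.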